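The compounds below may be only part of what the source reports. "The series", "measured", "known", "first", "only" and "open" are said of these compounds alone.

Measured in a functional assay on SW480 cells (Homo sapiens) for antiproliferative activity, read by MTT assay, with a stated time of 48 h; a lower number here means a stronger inhibitor, a higher number a weaker inhibitor:
- compound 1 `COC/C1=C/C[C@](C)(CCC=C(C)C)/C=C/[C@@H](OC(=O)C=C(C)C)[C@](C)(OC)/C=C/C1=O`: 14600 nM
- compound 2 `CC(C)=CCC[C@](C)(/C=C/[C@@H](OC(=O)C=C(C)C)[C@](C)(O)/C=C/C(=O)/C=C/N(C)C)CC=O`: 10300 nM

Compound 2 lies within the scatter of compound 1, so these two values do not separate. Compound 3 `CC(C)=CCC[C@](C)(/C=C/[C@@H](OC(=O)C=C(C)C)[C@](C)(O)/C=C/C(=O)/C=C/N1CCN(C)CC1)CC=O`, not yet measured, carries 4-methylpiperazin-1-yl in place of dimethylamino on a double-bonded chain carbon bound to a double-bonded chain carbon. Among the compounds with values here, no measured pair shows this change, so the only anchor is compound 2 at 10300 nM. No shift beyond the scatter is expected in this assay. The estimated step is a 1.1-fold lower number from compound 2 to compound 3 (0.06 log units; within the scatter). The estimate for compound 3 is 9000 nM, with an expected range of 3500 nM to 24000 nM.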

Compound 3, half-maximal inhibitory concentration: 12400 nM
Compound 3: the middle estimate sits 1.4-fold (0.14 log units) below what was measured, within the range that was stated.
By their numbers in this assay, from the lowest: compounds 2, 3 and 1 (each within the scatter of the next).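

In this assay the change from dimethylamino to 4-methylpiperazin-1-yl on a double-bonded chain carbon bound to a double-bonded chain carbon reads as a 1.2-fold higher number from compound 2 to compound 3 (0.08 log units; within the scatter) and the two values do not separate. This position therefore accepts a six-membered non-aromatic ring with 2 hetero atoms, 7 heavy atoms entering for 3, without a change that can be read in this assay. Nothing at hand bears on why this is so.

Going by these compounds, whether a morpholine ring, a primary amine or a carboxylic acid at this carbon would separate from compound 2 stays open. A single step also leaves open how far this holds for longer chains on the nitrogen.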